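This account rests on a few compounds, and the source may have more. Where it says the series, first, only, none or still open, it means among the compounds named here.

Compound 1 `CCCn1cnc2ncnc(N)c21` carries a propyl chain on its core. In a functional assay on CHO cells for antagonist activity at adenosine receptor A2b (Homo sapiens) (on this read-out lower numbers stand for stronger inhibition and higher numbers for weaker inhibition), compound 1 gives only a limit, > 30000 nM. Compound 2 `Nc1ncnc2ncn(CCCO)c12` differs from it by hydroxy in place of hydrogen on a saturated chain carbon, three bonds along the chain from an aromatic nitrogen. In this assay compound 2 likewise gives only a limit, > 30000 nM. The step that the two limits leave unreadable from compound 1 to compound 2 cannot be read, since the limit of > 30000 nM in this assay, at which 2 of the 3 values shown sit, applies to both. Compound 3 `CC(O)Cn1c(Br)nc2c(N)ncnc21` has another core; the difference between the two cores is not broken down here. In this assay compound 3 gives 640 nM. Compound 4 `Nc1ncnc2c1nc(Br)n2CC(O)CO` differs from compound 3 by hydroxy in place of hydrogen on a saturated chain carbon, two bonds along the chain from an oxygen on a saturated carbon. This is the same kind of change as before, though the place differs: earlier the hydroxy stood three bonds along the chain from an aromatic nitrogen, now two bonds along the chain from an oxygen on a saturated carbon. The measured example gives no size. Given that compound 3 gives 640 nM, compound 4 is expected to show a step of a 1.6-fold higher number from compound 3 to compound 4 (0.19 log units; within the scatter). Compound 4 is thus estimated at 1000 nM.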

Compound 4, inhibition constant: 7100 nM
Compound 4: the middle estimate sits 7.1-fold (0.85 log units) below what was measured, outside the stated range (above it).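

In this assay the change on the core of compound 3 gives an 11-fold higher number from compound 3 to compound 4 (1.05 log units; beyond the scatter) and so clearly weakens inhibition on that core. This single readable pair does not show that the change would act in the same direction, or by a similar size, on the core of compound 1. The step on that core cannot be read, because compound 1 and compound 2 both give only a limit and not a number: the limit of > 30000 nM in this assay, at which 2 of the 4 values shown sit.

The compounds shown leave open whether the weakening would carry over to any core where both partners give real numbers. They also leave open how an amine, a carboxylic acid or a longer chain in place of the added hydroxy would compare with compound 3.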